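The source may report more compounds than this note shows. Statements on the series, on what has been measured and on what is new or still open speak of the compounds shown alone.

Compound 1 `COc1cc(-c2nn(-c3cccc(NC(=O)c4cccc(C(F)(F)F)c4)c3)cc2-c2ccncc2)ccc1Cl` in a functional assay on MCF7 cells (Homo sapiens) for inhibition, read by sulforhodamine B assay, with a stated time of 48 h; a higher number here means that more compound is tolerated, a lower number that less compound is tolerated: > 50000 nM, a limit of the assay.
Compound 2 `COc1cc(-c2nn(-c3cccc(NC(=O)c4ccc(Cl)c(C(F)(F)F)c4)c3)cc2-c2ccncc2)ccc1Cl` in this assay: > 32500 nM, also a limit of the assay.

Compound 2 thus stands only at a limit, and the step that the two limits leave unreadable from compound 1 to compound 2 has no readable size, since both ends rest on limits the limit of > 50000 nM in this assay, at which 1 of the 2 values shown sits, and (the limit of > 32500 nM in this assay, at which 1 of the 2 values shown sits). Compound 3 `COc1cc(-c2nn(-c3cccc(NC(=O)c4ccccc4)c3)cc2-c2ccncc2)ccc1Cl` differs from compound 2 by phenyl in place of 4-chloro-3-(trifluoromethyl)phenyl on a carbonyl carbon. Among the measured compounds shown here, the single measured step concerns another place and gives no size, so no direction beyond the scatter is expected, and compound 3 is expected to sit at a limit again, with an expected step that the limit leaves unreadable from compound 2 to compound 3. For compound 3 the estimate is 60000 nM, with a range from 20000 nM to 200000 nM.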

Compound 3, concentration lethal to 50% of the cells: > 100000 nM
Compound 3: only a limit was reported; the forecaster's own chance of this, stated with the estimate: 75%; at least 1.6-fold (0.22 log units) between middle value and limit.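

Among the compounds shown here, compound 1, compound 2 and compound 3 all sit at limits in this assay, so no step among them can be read. The compounds shown leave open whether changing the group on the carbonyl carbon affects the read-out at all.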